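The compounds below may be only part of what the source reports. "The series", "measured", "known", "first", "only" and "open" are said of these compounds alone.

Compound 2 has the structure `COc1ccccc1-n1nncc1CN1C(=O)C2(C(C#N)=C(N)Oc3c2c2nc4ccccc4nc2c2ccccc32)c2ccccc21`. In a functional assay on A549 cells (Homo sapiens) for antiproliferative activity, read by MTT assay, with a stated time of 48 h (on this read-out lower numbers stand for stronger inhibition and higher numbers for weaker inhibition), compound 2 gives only a limit of the assay, > 50000 nM, and no number. Compound 1, with the structure `Cc1ccccc1-n1nncc1CN1C(=O)C2(C(C#N)=C(N)Oc3c2c2nc4ccccc4nc2c2ccccc32)c2ccccc21`, carries a methyl where compound 2 carries a methoxy on an aromatic carbon. In this assay compound 1 likewise gives only a limit, > 50000 nM. The step that the two limits leave unreadable from compound 1 to compound 2 therefore cannot be read, and both values rest at the limit of > 50000 nM in this assay, at which 2 of the 2 values shown sit.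

Compound 3 has the structure `N#CC1=C(N)Oc2c(c3nc4ccccc4nc3c3ccccc23)C12C(=O)N(Cc1cnnn1-c1ccc([N+](=O)[O-])cc1)c1ccccc12`. It differs from compound 2 by 4-nitrophenyl in place of 2-methoxyphenyl on an aromatic nitrogen. No measured step bears on this exchange: the single step shown, from compound 1 to compound 2, is unreadable, and the nearest neighbour, compound 2, offers only its limit > 50000 nM as a guide. Compound 3 is therefore estimated to sit at the limit as well, at 70000 nM in this assay, with a range from 20000 nM to 250000 nM. The expected step that the limit leaves unreadable from compound 2 to compound 3 is thus no change that the numbers could reveal beyond the scatter.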

Compound 3, half-maximal inhibitory concentration: > 50000 nM
Compound 3: only a limit was reported; the forecaster's own chance of this, stated with the estimate: 85%; the middle value does not contradict the limit.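

In this assay, compound 3 also gives only a limit, > 50000 nM, so no step among compound 1, compound 2 and compound 3 can be read: the limit of > 50000 nM in this assay, at which 3 of the 3 values shown sit.

The compounds shown leave open whether the aromatic group on the ring nitrogen matters at all in this assay, since none of the three gives an actual number.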